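A few compounds are considered here, and "the series" means these few. Any claim that something is new, unique, unknown or untested is made for them only; others in the source may bear on it.

For the measured compounds named here, in a functional assay on SK-OV-3 cells (Homo sapiens) for cytotoxicity, read by MTT assay, with a stated time of 48 h (a lower number here means a stronger inhibitor, a higher number a weaker inhibitor), the series so far has only two measured members. Compound 1 `C=CCn1c(-c2ccc(OC)cc2COCOC)cc2ccccc2c1=O` gives > 100000 nM, which is a limit of the assay and not a number. Going by the values given here, compound 2 `C=CCn1c(-c2cc(OC)c(OC)cc2COCOC)cc2ccccc2c1=O` gives 37700 nM, the only true number available in this assay. Between these two, methoxy in place of hydrogen on an aromatic carbon gives an at least 2.6-fold lower number from compound 1 to compound 2 (0.42 log units; beyond the scatter). Compound 3 `C=CCn1c(-c2cc(OC)c(OC)cc2C=O)cc2ccccc2c1=O` changes a different group, with formyl in place of (methoxymethoxy)methyl on an aromatic carbon. Among the compounds with values here, no measured step covers this swap, so the size of the next move is uncertain. Within the data shown here, the one guide is an at least 2.6-fold lower number from compound 1 to compound 2 (0.42 log units; beyond the scatter), which shows only that a single change on this part of the molecule can move the number beyond the scatter. The expected result is a 2.5-fold lower number from compound 2 to compound 3 (0.40 log units; beyond the scatter), a modest move toward a lower number. Compound 3 is estimated at 15000 nM, within an expected range of 4000 nM to 60000 nM.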

Compound 3, half-maximal inhibitory concentration: 85500 nM
Compound 3: the middle estimate sits 5.7-fold (0.76 log units) below what was measured; measured number above the stated range.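

Formyl in place of (methoxymethoxy)methyl gives a 2.3-fold higher number from compound 2 to compound 3 (0.36 log units; beyond the scatter) in this assay. For the compounds shown here, this shows that the group on this aromatic carbon, ortho to a large group, also matters, and that a change here can raise the number, whereas the only earlier step lowered it. The smaller group, with 2 heavy atoms against 5, does not give a lower number here, and the result leaves compound 3 nearer to the top reading of the assay, which is a limit: the limit of > 100000 nM in this assay, at which 1 of the 3 values shown sits.

With only one replacement shown at this position, the compounds cannot tell whether the size of the group, its oxygen atoms or the carbonyl of formyl drives the step. A simple hydroxymethyl, an amine or a carboxylic acid on this carbon would help separate these possibilities.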